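Replacing sec-butyl on a weakly active series

The compounds below may be only part of what the source reports. "The series", "measured", "known", "first", "only" and "open" are said of these compounds alone.

Values measured in a functional assay on HeLa cells (Homo sapiens) for inhibition, with a stated time of 72 h; a lower number here means a stronger inhibitor, a higher number a weaker inhibitor:
- compound 1 `CCCCNC(=O)C1(N(Cc2ccccc2)C(=O)[C@H](CC(=O)OC)NC(=O)OC(C)(C)C)CCN(Cc2ccccc2)CC1`: 36000 nM
- compound 2 `COC(=O)C[C@H](NC(=O)OC(C)(C)C)C(=O)N(C1CC1)C1(C(=O)NCc2ccccc2)CCN(Cc2ccccc2)CC1`: 7900 nM
- compound 3 `CC[C@H](C)[C@H](NC(=O)OC(C)(C)C)C(=O)N(Cc1ccccc1)C1(C(=O)NCc2ccccc2)CCN(Cc2ccccc2)CC1`: 10000 nM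

Compound 3, at 10000 nM, lies within the scatter of compound 2, at 7900 nM. Its number is lower than that of compound 1, and that gap is beyond the scatter.

Compound 4 `CN(C)C(=O)C[C@H](NC(=O)OC(C)(C)C)C(=O)N(Cc1ccccc1)C1(C(=O)NCc2ccccc2)CCN(Cc2ccccc2)CC1` carries (dimethylcarbamoyl)methyl in place of the sec-butyl of compound 3, on a saturated chain carbon bound to an amide-type nitrogen and a carbonyl carbon ((dimethylcarbamoyl)methyl in place of sec-butyl on a saturated chain carbon bound to an amide-type nitrogen and a carbonyl carbon).

For the measured compounds named here, no measured pair isolates this change. Compound 2 has a methyl ester chain on that carbon and gives 7900 nM, while compound 1 has the same chain and gives 36000 nM, but both also differ from compound 3 elsewhere. In this assay, only a small move towards a higher number is therefore expected, with no step beyond the scatter. The estimated step is a 1.4-fold higher number from compound 3 to compound 4 (0.15 log units; within the scatter). For compound 4 the estimated value is 14000 nM, with an expected range of 5500 nM to 36000 nM.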

Compound 4, half-maximal inhibitory concentration: 68000 nM
Beside the measured number, compound 4's estimate is 4.9-fold (0.69 log units) below it; the measured number lies above the stated range.
By their numbers in this assay, from the lowest: compounds 2 and 3 (each within the scatter of the next); then compounds 1 and 4 (each within the scatter of the next).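

In this assay, the saturated chain carbon bound to an amide-type nitrogen and a carbonyl carbon now has its first direct reading: (dimethylcarbamoyl)methyl in place of sec-butyl gives a 6.8-fold higher number from compound 3 to compound 4 (0.83 log units; beyond the scatter) with the rest of the structure unchanged. This position is therefore not indifferent to its substituent, and this change weakens a compound that was already only weakly active. No measurement here explains the loss or ties it to either group.

The compounds shown leave open how a methyl ester chain would read on the core of compound 3: compound 1 and compound 2 carry that chain but also differ elsewhere. They also leave open whether a carboxylic acid, an amine or a longer alkyl chain on this carbon would read closer to compound 3 or to compound 4.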